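The source may hold more compounds than are shown below. What is called first, only, known or untested is meant among the compounds shown, and "the series" means these compounds.

Of the compounds shown here, three of one series have so far been measured in a functional assay on A549 cells (Homo sapiens) for cytotoxicity, read by MTT assay, with a stated time of 72 h; a higher number here means a weaker inhibitor, a lower number a stronger inhibitor. Compound 1 `COc1cc2c(Oc3ccc(NC(=O)c4cn(-c5ccccc5)nn4)cc3F)ccnc2cc1OCCCN1CCC(C)CC1` gives 140 nM; compound 2 `COc1cc2c(Oc3ccc(NC(=O)c4cn(-c5ccccc5F)nn4)cc3F)ccnc2cc1OCCCN1CCC(C)CC1` gives 250 nM; compound 3 `COc1cc2c(Oc3ccc(NC(=O)c4cn(-c5c(C)cccc5C)nn4)cc3F)ccnc2cc1OCCCN1CCC(C)CC1` gives 3340 nM, the highest of the three numbers. The steps into compound 3 are a 24-fold higher number from compound 1 to compound 3 (1.38 log units; beyond the scatter) and a 13-fold higher number from compound 2 to compound 3 (1.13 log units; beyond the scatter), both at the aryl on the aromatic nitrogen, while a 1.8-fold higher number from compound 1 to compound 2 (0.25 log units; within the scatter). Compound 4 `COc1cc2c(Oc3ccc(NC(=O)c4cn(-c5c(C)cccc5C)nn4)cc3F)ccnc2cc1OCCCN1CCN(C)CC1` differs from compound 3 at a different site: 4-methylpiperazin-1-yl in place of 4-methylpiperidin-1-yl on a saturated chain carbon, three bonds along the chain from an oxygen on an aromatic ring. None of the measured steps touches this saturated chain carbon, so no shown step bears on the change. With nothing to point either way, the expectation for compound 4 in this assay is a 1.0-fold lower number from compound 3 to compound 4 (0.01 log units; within the scatter), none beyond the scatter. Compound 4 is therefore estimated at 3300 nM, with a range from 1200 nM to 9000 nM.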

Compound 4, half-maximal inhibitory concentration: 2180 nM
Compound 4: the middle estimate sits 1.5-fold (0.18 log units) above what was measured; measured number inside the range.
By their numbers in this assay, from the lowest: compounds 1 and 2 (each within the scatter of the next); then compounds 4 and 3 (each within the scatter of the next).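

In this assay, 4-methylpiperazin-1-yl in place of 4-methylpiperidin-1-yl gives a 1.5-fold lower number from compound 3 to compound 4 (0.19 log units; within the scatter) and so, in the 2,6-dimethylphenyl setting, the second ring hetero atom on this saturated chain carbon moves the number no further than the scatter. Going by these compounds alone, this is the first reading at this site, and it leaves the aryl on the aromatic nitrogen as the only place with steps beyond the scatter. No evidence bears on this result.

On these data alone, whether the same swap holds with the phenyl of compound 1 stays open. So does the outcome with a morpholine, a dimethylamino group or a shorter chain at this site.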